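The compounds below may be only part of what the source reports. "The series", "measured", "known", "first", "only" and "open" are said of these compounds alone.

Of the compounds shown here, two from this series have been tested in an ADME assay on PC-3 cells (Homo sapiens) for cytotoxicity, read by WST assay, tested at 100 uM; a lower number here means less inhibition, a higher number more inhibition at the concentration tested (going by the name of the read-out). Compound 1, `O=C(Nc1cccc(N2CCCC2=O)c1)C1CCCN(C(=O)c2cc(C(F)(F)F)cc(C(F)(F)F)c2)C1`, gives 0% in this assay, meaning no measurable effect on the cells at the concentration used. Compound 2, `O=C(Nc1ccc(Cl)cc1)C1CCCN(C(=O)c2cccc(-c3nccs3)c2)C1`, gives 32% in this assay. Going by the values given here, of the two numbers that are known, the one for compound 2 is the higher, and the gap of compound 1 below it lies beyond the usual scatter of this measurement, so the two compounds are clearly told apart.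

The next compound, compound 3, `C=Cc1cccc(C(=O)N2CCCC(C(=O)Nc3ccc(Cl)cc3)C2)c1`, differs from compound 2 in a single place: vinyl in place of 1,3-thiazol-2-yl on an aromatic carbon. The 1,3-thiazol-2-yl group leaves and a vinyl group enters on an aromatic carbon of a six-membered aromatic ring of carbon only. Among the compounds with values here, no pair of measured compounds shows what such a change does here, so the step can only be guessed. The expectation is a modest downward step, a number 10 percentage points lower from compound 2 to compound 3 (within the scatter), that may well stay inside the scatter. Compound 3 is therefore estimated to give 22% in this assay, within a range from 2% to 45%.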

Compound 3, a percentage reported as inhibition, at one concentration (the size of the read-out at that concentration, not a potency): 0%
Estimate against measurement, compound 3: 22 percentage points above; the whole stated range lies above it.
By their numbers in this assay, from the lowest: compounds 1 and 3 (each within the scatter of the next); then compound 2.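

Replacing the 1,3-thiazol-2-yl group with vinyl, on an aromatic carbon meta to a large group, gives a step of a number 32 percentage points lower from compound 2 to compound 3 (beyond the scatter) in this assay. This is the only pair shown that differs in one place, so it is the only direct view of what a single group does in this series. It shows that this position is not indifferent: with everything else in the molecule held the same, the group on this carbon alone separates a clear reading from none, and compound 3 gives 0% at the concentration tested.

No measured property of either group is at hand to explain the step.

The change alters several things at once, including the size of the group, the presence of a ring, and the presence of nitrogen, sulfur and hydrogen-bond acceptors, so the compounds shown do not reveal which of these matters. On these data alone, it remains open how the reading would respond to a phenyl ring, which keeps an aromatic ring without nitrogen or sulfur, or to an amine or a longer carbon chain on the same carbon.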